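The compounds below may be only part of what the source reports. "The series", "measured", "known", "first", "only" and "open" are said of these compounds alone.

Measured in a functional assay on THP-1 cells (Homo sapiens) for cytotoxicity, read by MTT assay, with a stated time of 24 h; a higher number here means a weaker inhibitor, a lower number a stronger inhibitor:
- Compound 1 `CCCCn1cc(Cn2nc(N)c3c(C(F)(F)F)cc(-c4ccccc4)nc32)nn1`: 46.1 ug/mL
- Compound 2 `CCCCCCCCCCn1cc(Cn2nc(N)c3c(C(F)(F)F)cc(-c4ccccc4)nc32)nn1`: 48.7 ug/mL
- Compound 3 `Cc1ccc(-n2cc(Cn3nc(N)c4c(C(F)(F)F)cc(-c5ccccc5)nc43)nn2)cc1`: 98.6 ug/mL

Compound 3 has the highest number of the three and is the weakest inhibitor in this small set. Two steps show this: a 2.1-fold higher number from compound 1 to compound 3 (0.33 log units; beyond the scatter) and a 2.0-fold higher number from compound 2 to compound 3 (0.31 log units; beyond the scatter). The two compounds with saturated chains cannot be told apart, as a 1.1-fold higher number from compound 1 to compound 2 (0.02 log units; within the scatter) shows.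

Compound 4 `Nc1nn(Cc2cn(CC(=O)Nc3ccccc3)nn2)c2nc(-c3ccccc3)cc(C(F)(F)F)c12` keeps the shared core and alters a single group of compound 3: (phenylcarbamoyl)methyl in place of 4-methylphenyl on an aromatic nitrogen. Put simply, (phenylcarbamoyl)methyl stands in place of 4-methylphenyl on an aromatic nitrogen.

The two steps into compound 3 bear most directly on this, since they exchange a group on that same nitrogen. Both are modest, so changes at this place have so far moved the number only a little. For the measured compounds named here, no measured compound carries the entering group, however, so the guide is loose. Compound 3 also sits at the top of the measured values, which makes a small move downward more likely than a further rise. The estimated change is a 1.4-fold lower number from compound 3 to compound 4 (0.15 log units; within the scatter), and no clear shift beyond the scatter is expected.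

For compound 4 the estimate is 70 ug/mL, with an expected range of 35 ug/mL to 140 ug/mL.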

Compound 4, half-maximal inhibitory concentration: 54.6 ug/mL
Compound 4: middle estimate off by 1.3-fold (0.11 log units), on the high side; measured number inside the range.
By their numbers in this assay, from the lowest: compounds 1, 2, 4 and 3 (each within the scatter of the next, the first and the last beyond it).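

For the compounds shown here, compound 4 cannot be told apart from any of the earlier compounds in this assay (a 1.8-fold lower number from compound 3 to compound 4 (0.26 log units; within the scatter) and a 1.1-fold higher number from compound 2 to compound 4 (0.05 log units; within the scatter) and a 1.2-fold higher number from compound 1 to compound 4 (0.07 log units; within the scatter)). This aromatic nitrogen therefore carries (phenylcarbamoyl)methyl, which brings a hydrogen-bond donor and a hydrogen-bond acceptor that 4-methylphenyl lacks, without the number shifting beyond the scatter from any earlier compound. Compound 4 also keeps a six-membered aromatic ring in its group and still lies within the scatter of compound 1 and compound 2, unlike compound 3, so such a ring alone does not set a compound apart from those with saturated chains.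

Why the numbers fall as they do remains open, as nothing measured here speaks to a cause. Also open, from the compounds shown here alone, is whether a carboxylic acid or an amine at the end of the group on this nitrogen, or a chain longer than decyl, would take the number clearly beyond the scatter of these four compounds.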